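This account rests on a few compounds, and the source may have more. Where it says the series, first, only, none or still open, it means among the compounds named here.

Measured so far:
- compound 1, `Cc1cc(Nc2ccc(C(=O)/C=C/c3ccc(OC(F)(F)F)c(OC(F)(F)F)c3)cc2)n2nc(SCc3nc4ccccc4[nH]3)nc2n1`: 120 nM
- compound 2, `COc1cc(OC)c(/C=C/C(=O)c2ccc(Nc3cc(C)nc4nc(SCc5nc6ccccc6[nH]5)nn34)cc2)c(OC)c1`: 260 nM
- compound 3, `Cc1cc(Nc2ccc(C(=O)/C=C/c3ccc4ccccc4c3)cc2)n2nc(SCc3nc4ccccc4[nH]3)nc2n1`: 28.2 nM

In a functional assay on SW-620 cells (Homo sapiens) for cytotoxicity, read by MTT assay, with stated times of 4 h and 72 h, tested at 1 uM (a higher number here means a weaker inhibitor, a lower number a stronger inhibitor), compound 3 gives the lowest number of the three, and its gaps to compound 1 and to compound 2 are both beyond the scatter, so it is the strongest inhibitor of the set. The three compounds share the same core and differ only in the aromatic group on the double-bonded chain carbon.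

Compound 4, `Cc1cc(Nc2ccc(C(=O)/C=C/c3cccc(Br)n3)cc2)n2nc(SCc3nc4ccccc4[nH]3)nc2n1`, is not yet measured. Its change from compound 3 is 6-bromopyridin-2-yl in place of naphthalen-2-yl on a double-bonded chain carbon bound to a double-bonded chain carbon. For the measured compounds named here, the one step measured at this position is a 9.2-fold lower number from compound 2 to compound 3 (0.96 log units; beyond the scatter), which shows that the group here moves the number well beyond the scatter. Going by the values given here, no measured step covers a single heteroaromatic ring or a bromine at this place, so the direction rests on that sensitivity alone. Since the two-ring group gave the lowest number, a smaller one-ring group is expected to give a higher number, in the direction of compound 1. Compound 4 is therefore estimated at 120 nM, range 35 nM to 400 nM, a step of a 4.3-fold higher number from compound 3 to compound 4 (0.63 log units; beyond the scatter).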

Compound 4, half-maximal inhibitory concentration: 58 nM
The estimate for compound 4 lay 2.1-fold (0.32 log units) above the measured number; the range from low to high includes it.
By their numbers in this assay, from the lowest: compound 3; then compound 4; then compound 1; then compound 2.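

In this assay, a 2.1-fold higher number from compound 3 to compound 4 (0.31 log units; beyond the scatter) shows that the two fused rings of naphthalen-2-yl can give way to a single ring at this place at a modest cost, with the number staying below those of the other one-ring compounds shown. a 4.5-fold lower number from compound 2 to compound 4 (0.65 log units; beyond the scatter) shows that a one-ring group does not by itself bring the high number of compound 2, so the identity of the ring and its substituents matters here, not only the ring count. Nothing available explains either step.

The ring nitrogen and the bromine enter together, so the compounds shown do not separate their contributions. An unsubstituted pyridin-2-yl, a 3-bromophenyl or a 6-aminopyridin-2-yl at this place would begin to separate them.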